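Adding a chlorine to a urea pair and an amide analogue

This account rests on a few compounds, and the source may have more. Where it says the series, first, only, none or still open, it means among the compounds named here.

Compound 1 `Nc1nccc2c1ccn2-c1ccc(NC(=O)Nc2cccc(C(F)(F)F)c2)cc1` and compound 2 `Nc1nccc2c1ccn2-c1ccc(NC(=O)Nc2ccc(Cl)c(C(F)(F)F)c2)cc1` share a core and differ in one place. The change is chloro in place of hydrogen on an aromatic carbon. In a functional assay on A-375 cells (Homo sapiens) for antiproliferative activity, read by MTT assay, with a stated time of 48 h, in the presence of a further agent that is not named here (on this read-out higher numbers stand for weaker inhibition and lower numbers for stronger inhibition), compound 1 gives 5400 nM, and compound 2 gives 8000 nM. The step is a 1.5-fold higher number from compound 1 to compound 2 (0.17 log units; within the scatter). These two numbers therefore cannot be told apart by this measurement.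

Compound 3 `O=C(Nc1ccc(-n2ccc3c(NC(=O)c4ccccc4)nccc32)cc1)c1cccc(C(F)(F)F)c1` is built on a different core, and the difference between the two cores is not broken down here. In this assay compound 3 gives 100 nM, the lowest of the three measured numbers, and its distance from compound 1 and from compound 2 is well beyond the scatter.

Compound 4 `O=C(Nc1ccc(-n2ccc3c(NC(=O)c4ccccc4)nccc32)cc1)c1ccc(Cl)c(C(F)(F)F)c1` is not yet measured. It differs from compound 3 as compound 2 differs from compound 1: the change is chloro in place of hydrogen on an aromatic carbon. The surroundings of the place are the same in both pairs, so this is the same change, made on the other core.

Among the measured compounds shown here, the only guide to the size of the step is the measured pair, where the step was a 1.5-fold higher number from compound 1 to compound 2 (0.17 log units; within the scatter). On that basis the step from compound 3 to compound 4 in this assay is expected to be a 1.4-fold higher number from compound 3 to compound 4 (0.15 log units; within the scatter), that is, a number hardly different from compound 3. The estimate for compound 4 in this assay is 140 nM, expected to lie between 50 nM and 400 nM. For the measured compounds named here, since only one earlier example of the change exists, and it sits on another core, the range is kept wide.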

Compound 4, half-maximal inhibitory concentration: 16.4 nM
Compound 4: the middle estimate sits 8.5-fold (0.93 log units) above what was measured, and the stated range ends above it.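

In this assay, among the compounds shown here, putting a chloro group on the 3-(trifluoromethyl)phenyl ring of compound 3 gives a 6.1-fold lower number from compound 3 to compound 4 (0.79 log units; beyond the scatter), so on this core the change brings clearly stronger inhibition, whereas on the core of compound 1 it produced no step that the measurement can resolve. For the compounds shown here, the effect of this change therefore did not carry over unchanged from one core to the other, and the earlier pair would have been a poor guide to its size here: the same change on two cores in this assay, a 1.5-fold higher number (0.17 log units; within the scatter) from compound 1 to compound 2 and a 6.1-fold lower number (0.79 log units; beyond the scatter) from compound 3 to compound 4, 9.0-fold (0.96 log units) apart, beyond the scatter of two such steps This rests on only two pairs, and the two cores differ in more than one place, so the result does not show which part of the core matters, why the steps differ, or how the change would behave on any further core.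

Going by these compounds, it remains open whether a bromine atom, a methyl group or a methoxy group at the same place on compound 4 would give a step like that of the chloro group. On these data alone, it also remains open whether the chloro group would give the same step if a nitrile took the place of the trifluoromethyl group.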